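The source may report more compounds than this note shows. Statements on the series, on what has been measured and on what is new or still open speak of the compounds shown alone.

For the measured compounds named here, in a functional assay on NFS-60 cells (Mus musculus) for inhibition, with a stated time of 72 h (on this read-out lower numbers stand for stronger inhibition of growth and higher numbers for weaker inhibition of growth), compound 3 (`Cc1cccc(Cn2nc(Cl)c3c(NC(=O)c4csc5c(N)ncnc45)cccc32)n1`) gives 8 nM, the lowest of the numbers so far. Compound 1 (`Nc1ncnc2c(C(=O)Nc3cccc4c3c(Br)nn4Cc3cccc(Br)n3)csc12`) gives a higher number, 243 nM. Compound 2 (`C#CCn1nc(Br)c2c(NC(=O)c3csc4c(N)ncnc34)cccc21`) gives > 10000 nM, which is a limit of the assay and not a number.

The next compound to be tested is compound 4 (`C=Cc1nn(Cc2cccc(C)n2)c2cccc(NC(=O)c3csc4c(N)ncnc34)c12`), which has vinyl in place of chloro on an aromatic carbon. This carbon sits on the five-membered aromatic ring with 2 nitrogen.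

Going by the values given here, only one measured step links two compounds that differ in one place: an at least 41-fold higher number from compound 1 to compound 2 (1.61 log units; beyond the scatter). That step is large and beyond the scatter, but its change lies on a saturated chain carbon bound to an aromatic nitrogen, not on the aromatic carbon that changes here. Compound 1 and compound 3 differ in more than one place, so the gap between their values does not isolate this carbon either. No measurement therefore bears directly on the swap, and no large step is expected from it. The expected step is a 1.9-fold higher number from compound 3 to compound 4 (0.27 log units; within the scatter), a slight rise in the number that is estimated to stay about at the edge of the scatter. For compound 4 the estimate is 15 nM, with an expected range from 4 nM to 80 nM.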

Compound 4, concentration for 50% growth inhibition: 4460 nM
For compound 4 the middle estimate is 300-fold (2.47 log units) below the measured one; the whole stated range lies below it.
By their numbers in this assay, from the lowest: compound 3; then compound 1; then compound 4. At a limit, above all of these: compound 2.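

Taken alone, the change from chloro to vinyl on this aromatic carbon of the five-membered aromatic ring with 2 nitrogen gives, in this assay, a 560-fold higher number from compound 3 to compound 4 (2.75 log units; beyond the scatter). For the compounds shown here, the earlier compounds offered only one single-place step, at a saturated chain carbon bound to an aromatic nitrogen, whereas this step holds the (6-methylpyridin-2-yl)methyl group fixed and shows that the aromatic carbon itself strongly affects growth inhibition, with a swap of just one chlorine for two carbons sufficient to weaken it sharply. The number for compound 4 is a measured value and not a limit, so this step can be read in full, and the only limit among the compounds shown belongs to compound 2: the limit of > 10000 nM in this assay, at which 1 of the 4 values shown sits.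

The compounds shown leave open whether the weaker inhibition follows from the added heavy atom or from the double bond outside aromatic rings, a question that an ethyl group, with its two carbons and no double bond, or a methyl group, with a single carbon, could help to settle. Bromo also sits on this carbon in compound 1, but that compound differs from compound 3 in more than one place, so the effect of bromo against chloro here remains unresolved.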